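A few compounds are considered here, and "the series" means these few. Any claim that something is new, unique, unknown or untested is made for them only; others in the source may bear on it.

Compound 1 `CC(=O)NC1=CS(=O)(=O)O[C@@]12[C@@H](CO[Si](C)(C)C(C)(C)C)O[C@@H](n1cc(C)c(=O)n(C)c1=O)[C@@H]2O[Si](C)(C)C(C)(C)C`: 10700 nM
Compound 2 `Cc1cn([C@@H]2O[C@@H]3COC(=O)[C@]3(OS(C)(=O)=O)[C@H]2O)c(=O)[nH]c1=O`: >= 250000 nM

Within the data shown here, in a functional assay on MT4 cells (Homo sapiens) (a higher number here means that more compound is tolerated, a lower number that less compound is tolerated), compound 1 gives 10700 nM, the only actual number available. Compound 2 stands at >= 250000 nM, which is a limit of the assay and not a number. Among the measured compounds shown here, the two structures also differ in more than one place, so no measured step serves as a guide.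

Compound 3 `CCOC(=O)CNC(=O)NC1=CS(=O)(=O)O[C@@]12[C@@H](CO[Si](C)(C)C(C)(C)C)O[C@@H](n1cc(C)c(=O)n(C)c1=O)[C@@H]2O[Si](C)(C)C(C)(C)C` keeps the core of compound 1 but carries ((ethoxycarbonyl)methyl)amino in place of methyl on a carbonyl carbon. Acetamido thereby becomes (((ethoxycarbonyl)methyl)carbamoyl)amino.

For the measured compounds named here, with no comparable step measured, the expectation rests on compound 1 at 10700 nM, and no shift beyond the scatter is foreseen in this assay, in either direction. The expected step of a 1.1-fold higher number from compound 1 to compound 3 (0.05 log units; within the scatter) is accordingly small. For compound 3 the estimated value is 12000 nM, with an expected range of 5000 nM to 30000 nM.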

Compound 3, half-maximal cytotoxic concentration: 3780 nM
Compound 3: middle estimate off by 3.2-fold (0.50 log units), on the high side; measured number below the stated range.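

In this assay the position on the carbonyl carbon proves sensitive to change: ((ethoxycarbonyl)methyl)amino in place of methyl gives a 2.8-fold lower number from compound 1 to compound 3 (0.45 log units; beyond the scatter) and so less compound is tolerated. Among these compounds, the step is modest but lies beyond the scatter, and it is the first comparison here in which only one place differs. Nothing measured here accounts for the shift.

Going by these compounds, what stays open is which part of the new group goes with the lower number, the amino link or the ethyl ester at the end of the chain. A plain amino group on the same carbonyl carbon, a carboxylic acid in place of the ethyl ester or a longer chain before the ester would each separate these parts, and none of them is among the compounds shown.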